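A Chloro Substituent and Cytotoxicity on Leukemia Cells

A few compounds are considered here, and "the series" means these few. Any claim that something is new, unique, unknown or untested is made for them only; others in the source may bear on it.

Of the compounds shown here, two have been measured in a functional assay on CCRF-CEM cells (Homo sapiens) for cytotoxicity, read by MTT assay, with a stated time of 48 h, tested at 25 uM; a lower number here means a stronger effect, a higher number a weaker effect of the compound at the concentration tested. Compound 1 `Clc1ccccc1-c1nnn(CCCn2cnc3c(Br)c(Br)c(Br)c(Br)c32)n1` gives 89%. Going by the values given here, compound 2 `Brc1c(Br)c(Br)c2c(ncn2CCCn2nnnc2-c2ccccc2)c1Br` gives 0%, the lower of the two numbers; the only other number, that of compound 1, stands higher by a gap beyond the usual scatter. Compound 3 `Clc1ccccc1-c1nnnn1CCCn1cnc2c(Br)c(Br)c(Br)c(Br)c21` has not yet been measured. It differs from compound 2 in one place: chloro in place of hydrogen on an aromatic carbon. Compound 1 and compound 2 differ from each other in more than this one place, so their gap cannot be read as the effect of the chloro alone. Among the compounds with values here, for compound 3 in this assay, a rise beyond the scatter is expected, the step from compound 2 being estimated as a number 40 percentage points higher from compound 2 to compound 3 (beyond the scatter), because compound 1, the only measured compound carrying the chloro, gives 89%. Compound 3 is thus estimated at 40%, with a wide range from 5% to 85%.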

Compound 3, a percentage reported as inhibition, at one concentration (the size of the read-out at that concentration, not a potency): 1%
Estimate against measurement, compound 3: 39 percentage points above, outside the stated range (below it).
By their numbers in this assay, from the lowest: compounds 2 and 3 (each within the scatter of the next); then compound 1.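

Going from phenyl to 2-chlorophenyl, with the chloro on an aromatic carbon ortho to a large group, gives a number 1 percentage points higher from compound 2 to compound 3 (within the scatter) in this assay on these leukemia cells. Compound 3 carries the same chloro as compound 1, yet compound 1 gives 89% and compound 3 gives 1% at the one concentration tested, so the chloro alone is not enough to produce the high number of compound 1. Nothing measured here offers an explanation for this result.

On these data alone, whether an amine or a carboxylic acid on the same aromatic carbon would give a different number remains open. So does the outcome of a longer chain linking the phenyl-bearing ring to the shared core.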